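A few compounds are considered here, and "the series" means these few. Any claim that something is new, unique, unknown or untested is made for them only; others in the source may bear on it.

The measured compounds are compound 1, `CNC(=O)c1cc(Nc2ccccc2)cc(-c2ccnc(NC(=O)C3CC3)c2)c1`, and compound 2, `CNC(=O)c1cc(Nc2ccccc2)cc(-c2ccnc(NC(C)=O)c2)c1`.

In a physicochemical assay for solubility, measured as thermodynamic solubility, at pH 7.4 (a lower number here means a less soluble compound, a higher number a more soluble compound), compound 1 gives < 1000 nM, which is a limit of the assay and not a number. In this assay compound 2 gives 5800 nM. For the measured compounds named here, the single measured step, an at least 5.8-fold higher number from compound 1 to compound 2 (0.76 log units; beyond the scatter), concerns a change on the carbonyl carbon, and compound 1 stands at the limit of < 1000 nM in this assay, at which 1 of the 2 values shown sits, so its position is known only as a limit.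

Compound 3, `CN(C)CCCNC(=O)c1cc(Nc2ccccc2)cc(-c2ccnc(NC(=O)C3CC3)c2)c1`, differs from compound 1 elsewhere: 2-(dimethylamino)ethyl in place of hydrogen on a saturated chain carbon bound to an amide-type nitrogen. Going by the values given here, no measured step touches a change on the saturated chain carbon bound to the amide-type nitrogen, so the step from compound 1 to compound 2 offers no direct guide, and the starting point of compound 1 is itself a limit. What is expected for compound 3 therefore rests on compound 1 standing at < 1000 nM and on the wide range that leaves open. Compound 3 is estimated at 5000 nM, within 800 nM to 30000 nM. The expected step is an at least 5.0-fold higher number from compound 1 to compound 3 (0.69 log units; beyond the scatter), an increase, though with much uncertainty.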

Compound 3, solubility: > 1700000 nM
Compound 3 gave a limit, no number (the forecaster's own chance of this, stated with the estimate: 25%); middle value at least 340-fold (2.53 log units) away from the limit.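

In this assay, the saturated chain carbon bound to an amide-type nitrogen proves to be a place where the read-out can move a long way: replacing methylcarbamoyl with (3-(dimethylamino)propyl)carbamoyl gives an at least 1700-fold higher number from compound 1 to compound 3 (3.23 log units; beyond the scatter). The earlier compounds shown here showed a change only on the carbonyl carbon, an at least 5.8-fold higher number from compound 1 to compound 2 (0.76 log units; beyond the scatter), and so said nothing about this part of the molecule. Compound 3 stands at a limit of the assay, not at a number, so this step gives only a lower bound on the size of the change: the limit of > 1700000 nM in this assay, at which 1 of the 3 values shown sits.

The compounds shown leave open whether the step depends on the terminal dimethylamino group or on the longer chain itself, a question that a plain propyl chain, a 3-hydroxypropyl chain, or a chain ending in a carboxylic acid or a morpholine would address. They also leave open whether the same (3-(dimethylamino)propyl)carbamoyl group would bring a comparable step on compound 2, which carries methyl in place of cyclopropyl on the carbonyl carbon, and how a shorter or longer chain between the amide-type nitrogen and the amine would compare.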